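The source may report more compounds than this note shows. Statements on the series, on what has been measured and on what is new or still open speak of the compounds shown alone.

Compound 1 `O=C(/C=C/c1cccc2ccccc12)c1cccc(NC(=O)c2cc(-c3ccncc3)n[nH]2)c1`: 72100 nM in a functional assay, read by spectrophotometry, tested at 100 uM; on this read-out lower numbers stand for stronger inhibition and higher numbers for weaker inhibition. Compound 2 `O=C(/C=C/c1ccc(F)cc1)c1cccc(NC(=O)c2cc(-c3ccncc3)n[nH]2)c1`: 58700 nM.

Compound 1 gives the highest of the two numbers in this assay, and its nearest neighbour is compound 2, at a 1.2-fold lower number from compound 1 to compound 2 (0.09 log units; within the scatter). Compound 3 `O=C(/C=C/c1ccccc1Cl)c1cccc(NC(=O)c2cc(-c3ccncc3)n[nH]2)c1` differs from compound 1 in one place: 2-chlorophenyl in place of naphthalen-1-yl on a double-bonded chain carbon bound to a double-bonded chain carbon. For the measured compounds named here, the only measured step that bears on this change is a 1.2-fold lower number from compound 1 to compound 2 (0.09 log units; within the scatter), which lay within the scatter. A step of a similar size is therefore expected, a 1.2-fold lower number from compound 1 to compound 3 (0.07 log units; within the scatter), with no direction beyond the scatter. Compound 3 is estimated at 62000 nM, within 30000 nM to 130000 nM.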

Compound 3, half-maximal inhibitory concentration: 79800 nM
Compound 3: middle estimate off by 1.3-fold (0.11 log units), on the low side, within the range that was stated.
By their numbers in this assay, from the lowest: compounds 2, 1 and 3 (each within the scatter of the next).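

In this assay the change to 2-chlorophenyl gives a 1.1-fold higher number from compound 1 to compound 3 (0.04 log units; within the scatter) and, measured against the fluorinated compound, a 1.4-fold higher number from compound 2 to compound 3 (0.13 log units; within the scatter) with both steps inside the scatter. On a double-bonded chain carbon bound to a double-bonded chain carbon, naphthalen-1-yl, 4-fluorophenyl and 2-chlorophenyl therefore read alike, whether the group has two rings or one and whichever halogen it carries. No available evidence accounts for this sameness. On these data alone, all three groups are aromatic carbon rings, so what an amine or a carboxylic acid at this place would do remains open.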